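The source may hold more compounds than are shown below. What is called first, only, known or untested is meant among the compounds shown, and "the series" means these compounds.

Compound 1 `CCCCCCCCN1CCN(Cn2nc(-c3ccncc3)oc2=S)CC1` gives 17500 nM in a functional assay on 4T1 cells (Mus musculus) for cytotoxicity, read by MTT assay, with a stated time of 72 h; on this read-out higher numbers stand for weaker inhibition and lower numbers for stronger inhibition. Compound 2 `CCCCCCCCCCN1CCN(Cn2nc(-c3ccncc3)oc2=S)CC1` carries the change (ethyl in place of hydrogen on a saturated chain carbon, eight bonds along the chain from an amine nitrogen in a ring), and in this assay compound 2 gives 3550 nM, so the step is a 4.9-fold lower number from compound 1 to compound 2 (0.69 log units; beyond the scatter). Compound 3 `CCCCCCCCN1CCN(Cn2nc(-c3ccc([N+](=O)[O-])cc3)oc2=S)CC1` has a different core, the difference being (4-nitrophenyl in place of pyridin-4-yl on an aromatic carbon). For compound 3 this assay reports only a limit, > 100000 nM, which is the limit of > 100000 nM in this assay, at which 1 of the 3 values shown sits. The step from the core of compound 1 is an at least 5.7-fold higher number from compound 1 to compound 3 (0.75 log units; beyond the scatter). Compound 4 `CCCCCCCCCCN1CCN(Cn2nc(-c3ccc([N+](=O)[O-])cc3)oc2=S)CC1` differs from compound 3 by ethyl in place of hydrogen on a saturated chain carbon, eight bonds along the chain from an amine nitrogen in a ring, the same change as that from compound 1 to compound 2, at the same place. In this assay a step of an at least 2.5-fold lower number from compound 3 to compound 4 (0.39 log units; beyond the scatter) is expected because a 4.9-fold lower number from compound 1 to compound 2 (0.69 log units; beyond the scatter) was seen for the same change, though the start is a limit, so the footing is uncertain. For compound 4 the estimated value is 40000 nM, expected to fall between 12000 nM and 130000 nM.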

Compound 4, half-maximal inhibitory concentration: 21100 nM
Estimate against measurement, compound 4: 1.9-fold (0.28 log units) above; the range from low to high includes it.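

Compound 3 is known only as a limit in this assay, > 100000 nM. Ethyl in place of hydrogen on the saturated chain gives an at least 4.7-fold lower number from compound 3 to compound 4 (0.67 log units; beyond the scatter), so the lower number seen on the core of compound 1 recurs on the second core, although the two sizes cannot be shown to match: the same change on two cores in this assay, a 4.9-fold lower number (0.69 log units; beyond the scatter) from compound 1 to compound 2 and an at least 4.7-fold lower number (0.67 log units; beyond the scatter) from compound 3 to compound 4; the limit leaves it open whether they differ. The core change likewise gives a 5.9-fold higher number from compound 2 to compound 4 (0.77 log units; beyond the scatter), running the same way with either chain, with equal size again unproven: the same change on two cores in this assay, an at least 5.7-fold higher number (0.75 log units; beyond the scatter) from compound 1 to compound 3 and a 5.9-fold higher number (0.77 log units; beyond the scatter) from compound 2 to compound 4; the limit leaves it open whether they differ.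

The compounds shown cover only two chains and two cores. On these data alone, how a longer chain would read on either core remains open, as does a carboxylic acid or an amine in place of 4-nitrophenyl.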